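The compounds below may be only part of what the source reports. "The series", "measured", "known", "first", "only" and "open" are said of these compounds alone.

Compound 1, with the structure `CCCC/N=C(/N)NC(=O)c1cccc(F)c1CCc1cc(Br)ccc1OC`, has no number of its own in a functional assay for antagonist activity at Melanocortin receptor 4 (Homo sapiens), read by cAMP accumulation; on this read-out higher numbers stand for weaker inhibition and lower numbers for stronger inhibition: its entry there reads "not determined" (no result reported), so it stands nowhere on this read-out and gives no fixed point from which a step could be sized. Within the data shown here, the one measured neighbour is compound 2, `CCN(CC)CCCC(C)/N=C(/N)NC(=O)c1cccc(F)c1CCc1cc(Br)ccc1OC`, which in this assay gives 130 nM. Compound 3, `COc1ccc(Br)cc1CCc1c(F)cccc1C(=O)/N=C(\N)NCC(C)C`, shares every atom with compound 1, but the atoms are joined differently: it carries a group of 8 heavy atoms (5 carbon, 3 nitrogen; no ring) in place of a group of 8 heavy atoms (5 carbon, 3 nitrogen; no ring), on a carbonyl carbon. Among the measured compounds shown here, with no value for compound 1, no step between compound 1 and compound 3 can be expected in either direction, only a standalone guess. Compound 3 is estimated to give about 300 nM in this assay, expected to lie between 60 nM and 1500 nM.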

Compound 3, half-maximal inhibitory concentration: 8500 nM
For compound 3 the middle estimate is 28-fold (1.45 log units) below the measured one, and the stated range ends below it.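

Among these compounds, compound 1 has no number in this assay and no step from it to compound 3 can be read. The compounds shown leave open whether exchanging one chain for the other on the carbonyl carbon strengthens or weakens inhibition. Nothing shown offers an explanation for the value of compound 3.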